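Removing one methyl from compound 1

A few compounds are considered here, and "the series" means these few. Any claim that something is new, unique, unknown or untested is made for them only; others in the source may bear on it.

In a functional assay on thoracic aorta (Rattus norvegicus, strain Wistar), with a stated time of 15 min (on this read-out lower numbers stand for an effect already at smaller amounts and higher numbers for an effect only at larger amounts of compound), compound 1 `CC(C)Oc1ccc(Br)cc1C(C)NC(=O)N(C)S(=O)(=O)c1ccccc1` gives 32100 nM and lies within the scatter of compound 2 `CCOc1ccc(Br)cc1C(C)NC(=O)N(C)S(=O)(=O)c1ccccc1` at 19800 nM and compound 3 `COc1ccc(Br)cc1C(C)NC(=O)N(C)S(=O)(=O)c1ccccc1` at 16800 nM on this read-out. Compound 4 `CC(C)Oc1ccc(Br)cc1C(C)NC(=O)NS(=O)(=O)c1ccccc1` differs from compound 1 by a single change (hydrogen in place of methyl on an amide-type nitrogen): hydrogen in place of methyl on an amide-type nitrogen. The measured steps of a 1.6-fold lower number from compound 1 to compound 2 (0.21 log units; within the scatter) and a 1.9-fold lower number from compound 1 to compound 3 (0.28 log units; within the scatter) and a 1.2-fold lower number from compound 2 to compound 3 (0.07 log units; within the scatter) all stay within the scatter, but all concern the group on the oxygen, so none reaches this nitrogen. For the measured compounds named here, no measurement yet shows a direction, so only a modest, uncertain shift is expected in this assay, and the estimated step is a 1.6-fold lower number from compound 1 to compound 4 (0.21 log units; within the scatter) as a best guess. For compound 4 the estimated value is 20000 nM (expected range 4000 nM to 80000 nM).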

Compound 4, half-maximal effective concentration: 143000 nM
For compound 4 the middle estimate is 7.2-fold (0.85 log units) below the measured one; measured number outside the range, above it.
By their numbers in this assay, from the lowest: compounds 3, 2 and 1 (each within the scatter of the next); then compound 4.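

Unlike the changes to the group on the oxygen, which all stayed within the scatter, this change on the amide-type nitrogen gives a step beyond it in this assay (a 4.5-fold higher number from compound 1 to compound 4 (0.65 log units; beyond the scatter)). Among these compounds, then, the methyl on this nitrogen counts for more than the group on the oxygen. Nothing available explains this step.

From the compounds shown here alone, whether an ethyl group or a longer chain on this nitrogen would keep the number near that of compound 1 remains open. So does whether losing the methyl gives a similar step when the oxygen carries a methyl or ethyl group.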